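A few compounds are considered here, and "the series" means these few. Any claim that something is new, unique, unknown or untested is made for them only; others in the source may bear on it.

Compound 1 `CN1CCN(c2nc(Nc3ccc(C#N)c(C(F)(F)F)c3)nc(Oc3ccnc4ccccc34)n2)CC1` gives in a functional assay on DU-145 cells (Homo sapiens) for cytotoxicity, read by sulforhodamine B assay, with a stated time of 48 h (a higher number here means that more compound is tolerated, a lower number that less compound is tolerated), a value of > 100000 nM, which is a limit of the assay and not a number.
Compound 2 `CC(C)N1CCN(c2nc(Nc3ccc(C#N)c(C(F)(F)F)c3)nc(Oc3ccnc4ccccc34)n2)CC1` gives in this assay a value of > 100000 nM, again a limit of the assay rather than a number.

Compound 3 `N#Cc1ccc(Nc2nc(Oc3ccnc4ccccc34)nc(N3CCCCC3)n2)cc1C(F)(F)F` has not yet been measured in this assay. Among the compounds with values here, compound 2 stands at the top of what the assay can report: the only evidence available is the limit of > 100000 nM in this assay, at which 2 of the 2 values shown sit, so neither compound shows any cell killing within the tested range, and the one measured step, a step that the two limits leave unreadable from compound 1 to compound 2, cannot be given a size or a direction. The change to compound 3 is piperidin-1-yl in place of 4-isopropylpiperazin-1-yl on an aromatic carbon. Within the data shown here, no measured step covers a change of this kind, and the single step available is unreadable, so the expectation rests on the shared core alone. Compound 3 is expected, on this basis, to sit near the same limit, with a step of an at least 1.4-fold lower number from compound 2 to compound 3 (0.15 log units; that floor lies within the scatter) from compound 2 that is not expected to go beyond the scatter. The estimate for compound 3 in this assay is 70000 nM, within a range of 10000 nM to 300000 nM.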

Compound 3, concentration lethal to 50% of the cells: > 100000 nM
Compound 3: no number, only a limit; the forecaster's own chance of this, stated with the estimate: 60%; middle value at least 1.4-fold (0.15 log units) from the limit.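

Compound 3 gives the same kind of reading as compound 1 and compound 2, so no step among these three compounds can be read, either in size or in direction: the limit of > 100000 nM in this assay, at which 3 of the 3 values shown sit.

The compounds shown leave open whether any change at this place on the shared core would give a real number in this assay.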